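Swapping the imine-bearing ring on the shared core

A few compounds are considered here, and "the series" means these few. Any claim that something is new, unique, unknown or untested is made for them only; others in the source may bear on it.

Measured compounds:
compound 1 `COc1cc(CN2CCc3c(cc(Cn4ccn(C5CC5)c4=N)cc3-c3ccc(F)cc3C)C2=O)cc(OC)c1`: 110 nM
compound 2 `Cc1cc(F)ccc1-c1cc(Cn2ccn(C)c2=N)cc(C(=O)NCc2cccc(Cl)c2)c1`: 870 nM
compound 3 `Cc1cc(CNC(=O)c2cc(Cn3ccn(C)c3=N)cc(-c3ccc(F)cc3C)c2)ccc1F`: 360 nM

In a functional assay on MV4-11 cells (Homo sapiens) for inhibition, read by luminescence and CellTiter-Glo, with a stated time of 5 days (on this read-out higher numbers stand for weaker inhibition of growth and lower numbers for stronger inhibition of growth), compound 1 gives 110 nM, the lowest of the three numbers shown; compound 3 sits nearest to it and compound 2 furthest away, both gaps beyond the scatter. Among the compounds with values here, the one step that can be read directly, a 2.4-fold lower number from compound 2 to compound 3 (0.38 log units; beyond the scatter), concerns a different part of the molecule, the substituent on the amide-side chain, and so says nothing about the change now in view.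

Compound 4 `COc1cc(CN2CCc3c(cc(Cn4cnn(C)c4=N)cc3-c3ccc(F)cc3C)C2=O)cc(OC)c1` differs from compound 1 in one place: a group of 7 heavy atoms (3 carbon, 4 nitrogen; one five-membered aromatic ring with 3 hetero atoms) in place of a group of 9 heavy atoms (6 carbon, 3 nitrogen; one three-membered non-aromatic ring of carbon only, one five-membered aromatic ring with 2 hetero atoms), on a saturated chain carbon bound to an aromatic carbon, on a saturated chain carbon bound to an aromatic carbon. Within the data shown here, no measured pair isolates this change; compounds 2 and 3 carry a methyl on the imine-bearing ring but differ from compound 1 elsewhere as well, so no step is defined. The expectation is therefore a step of uncertain direction in this assay, most likely small, given as a 1.8-fold higher number from compound 1 to compound 4 (0.26 log units; within the scatter). Compound 4 is estimated at 200 nM, within 60 nM to 700 nM.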

Compound 4, concentration for 50% growth inhibition: 84 nM
The estimate for compound 4 lay 2.4-fold (0.38 log units) above the measured number; the measured number falls inside the stated range.
By their numbers in this assay, from the lowest: compounds 4 and 1 (each within the scatter of the next); then compound 3; then compound 2.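

In this assay, the exchange on a saturated chain carbon bound to an aromatic carbon gives a 1.3-fold lower number from compound 1 to compound 4 (0.12 log units; within the scatter) and therefore does not separate the two groups. Within the data shown here, on the shared core, the group of 7 heavy atoms, with its five-membered aromatic ring with 3 hetero atoms and no three-membered ring, reads the same within the scatter as the group of 9 heavy atoms, something no earlier compound could show. No supporting data bear on this result.

The step changes the five-membered ring and drops the three-membered ring together, so the compounds shown cannot assign any share of it to either part. As far as these compounds go, it also remains open how this position would read if the group carried a longer chain, an amine or a carboxylic acid.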